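A few compounds are considered here, and "the series" means these few. Any claim that something is new, unique, unknown or untested is made for them only; others in the source may bear on it.

Of the compounds shown here, three have so far been measured in a functional assay on MCF7 cells (Homo sapiens) for inhibition, read by sulforhodamine B assay, with a stated time of 48 h (on this read-out higher numbers stand for weaker inhibition of growth and lower numbers for stronger inhibition of growth), on this read-out. Here compound 1 (`c1ccc(Oc2ccc(NC3=NCCO3)cc2)cc1`) gives 3500 nM and compound 2 (`c1ccc(COc2cccc(NC3=NCCO3)c2)cc1`) gives 2600 nM in the same test. Compound 3 (`O=C(CCl)NC(=O)Nc1cccc(OC2CCCC2)c1`) gives 6200 nM as its result. That number lies within the usual scatter of compound 1 and above compound 2 by more than the scatter.

Compound 4 (`O=C(CCl)NC(=O)Nc1cccc(OC2CCCCCC2)c1`) differs from compound 3 in one place: it has cycloheptyl in place of cyclopentyl on an oxygen on an aromatic ring. For the measured compounds named here, no two measured compounds differ in only one place, and the data offer no direct guide to this ring change. With compound 3 at 6200 nM as the starting point, only a small shift is expected, most likely none beyond the scatter, with a slight lean towards a lower number. The expected change is a 1.2-fold lower number from compound 3 to compound 4 (0.09 log units; within the scatter) in this assay on this estimate. The estimated value for compound 4 is 5000 nM with an expected range from 2200 nM to 11000 nM in this test.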

Compound 4, concentration for 50% growth inhibition: 7200 nM
Beside the measured number, compound 4's estimate is 1.4-fold (0.16 log units) below it; measured number inside the range.
By their numbers in this assay, from the lowest: compounds 2, 1, 3 and 4 (each within the scatter of the next, the first and the last beyond it).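

In this assay, replacing cyclopentyl with cycloheptyl on an oxygen on an aromatic ring gives a 1.2-fold higher number from compound 3 to compound 4 (0.06 log units; within the scatter) and so leaves the two compounds indistinguishable. For the compounds shown here, this is the first direct comparison at this position: going from a five-membered to a seven-membered carbon ring does not shift the growth-inhibition number beyond the usual scatter. No supporting data bear on why the number stays put.

The compounds shown carry only these two carbon rings at this position, so it remains open whether a small cyclopropyl, a flat phenyl ring or a chain ending in an amine would move the number beyond the scatter. This single step also cannot show whether the same ring change would be as quiet on a different core.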